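This account rests on a few compounds, and the source may have more. Where it says the series, first, only, none or still open, it means among the compounds named here.

Of the compounds shown here, three sharing one core have been measured in a functional assay on HepG2 cells (Homo sapiens) for antiproliferative activity, read by MTT assay, with a stated time of 72 h; on this read-out lower numbers stand for stronger inhibition and higher numbers for weaker inhibition. Compound 1 (`N#Cc1ccc(/C=N/NC(=O)Nc2ccc(Oc3ccnc4[nH]ccc34)c(F)c2)cc1`) gives 850 nM, compound 2 (`O=C(N/N=C/c1ccc([N+](=O)[O-])cc1)Nc1ccc(Oc2ccnc3[nH]ccc23)c(F)c1`) gives 3030 nM, and compound 3 (`COc1ccc(/C=N/NC(=O)Nc2ccc(Oc3ccnc4[nH]ccc34)c(F)c2)c(OC)c1OC`) gives 2990 nM. Compound 2 therefore stands at the weaker end of this small set, level with compound 3.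

Compound 4 (`O=C(N/N=C/c1ccc(O)c(Br)c1)Nc1ccc(Oc2ccnc3[nH]ccc23)c(F)c1`) keeps the core of compound 2 but exchanges a whole aromatic group: 3-bromo-4-hydroxyphenyl in place of 4-nitrophenyl on a carbon with a double bond to nitrogen. Here 3-bromo-4-hydroxyphenyl comes in place of 4-nitrophenyl on a carbon with a double bond to nitrogen.

For the measured compounds named here, only one measured step bears on this directly. The step of a 3.6-fold higher number from compound 1 to compound 2 (0.55 log units; beyond the scatter) is modest and comes from nitro in place of cyano on an aromatic carbon. Going by the values given here, no measured compound carries the entering bromo and hydroxy groups, so the data give little guidance on direction. The expected change in this assay is therefore no larger than that modest step, and the estimated step is a 1.5-fold lower number from compound 2 to compound 4 (0.18 log units; within the scatter). For compound 4 the estimated value is 2000 nM, with an expected range from 700 nM to 6000 nM.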

Compound 4, half-maximal inhibitory concentration: 1360 nM
Beside the measured number, compound 4's estimate is 1.5-fold (0.17 log units) above it, and the stated range covers the measured number.
By their numbers in this assay, from the lowest: compounds 1 and 4 (each within the scatter of the next); then compounds 3 and 2 (each within the scatter of the next).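

In this assay, 3-bromo-4-hydroxyphenyl in place of 4-nitrophenyl on a carbon with a double bond to nitrogen gives a 2.2-fold lower number from compound 2 to compound 4 (0.35 log units; beyond the scatter) and so shows that exchanging the whole aromatic group can move the number beyond the scatter, here towards stronger inhibition. Set against the 4-cyanophenyl group of compound 1, the same group gives a 1.6-fold higher number from compound 1 to compound 4 (0.20 log units; within the scatter) and stays within the scatter, so two quite differently substituted aromatic groups cannot be told apart at this position. Nothing shown offers an explanation for the step from the nitro compound, and the bromo and hydroxy groups cannot be separated here.

Rings carrying the bromo or the hydroxy group alone would show which of the two matters. An amine or a carboxylic acid on the ring, or a saturated chain in its place, also remains an open question.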